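Pyrrolidinyl versus Azetidinyl Carbamate on the Amide Nitrogen

This account rests on a few compounds, and the source may have more. Where it says the series, first, only, none or still open, it means among the compounds named here.

Among the measured compounds shown here, compound 2 `CCN(CC)S(=O)(=O)c1ccc(S(=O)(=O)N2CCC[C@@H](C(=O)NC3CN(C(=O)OC(C)(C)C)C3)C2)cc1` gives 1800 nM in a functional assay on BXPC-3 cells (Homo sapiens) for inhibition, read by MTT assay, with a stated time of 7 days (a higher number here means a weaker inhibitor, a lower number a stronger inhibitor), the highest of the two numbers measured so far. For the measured compounds named here, compound 1 `CCN(CC)S(=O)(=O)c1ccc(S(=O)(=O)N2CCC[C@@H](C(=O)N[C@@H]3CCN(C(=O)OC(C)(C)C)C3)C2)cc1` gives 400 nM in this assay, and the only measured step, a 4.5-fold higher number from compound 1 to compound 2 (0.65 log units; beyond the scatter), is beyond the scatter. Compound 3 `CCN(CC)S(=O)(=O)c1ccc(S(=O)(=O)N2CCC[C@@H](C(=O)N[C@H]3CCN(C(=O)OC(C)(C)C)C3)C2)cc1` is not yet measured. It differs from compound 2 in one place: 1-(tert-butoxycarbonyl)pyrrolidin-3-yl in place of 1-(tert-butoxycarbonyl)azetidin-3-yl on an amide-type nitrogen. This is the reverse of the change that separates compound 1 from compound 2, except that the pyrrolidine stereocentre entering in compound 3 is the opposite one to that in compound 1; no measurement shows what that configuration does. The step from compound 1 to compound 2 is therefore the only bearing on the question, and run backwards it suggests a number lower than that of compound 2. The expected step is a 3.0-fold lower number from compound 2 to compound 3 (0.48 log units; beyond the scatter), with the configuration left uncertain and the range widened for it. Compound 3 is estimated at 600 nM in this assay, within 200 nM to 2500 nM.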

Compound 3, half-maximal inhibitory concentration: 300 nM
Compound 3: middle estimate off by 2.0-fold (0.30 log units), on the high side; low and high end bracket the measured number.
By their numbers in this assay, from the lowest: compounds 3 and 1 (each within the scatter of the next); then compound 2.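

In this assay, the change on the amide-type nitrogen now has a second reading, with a 6.0-fold lower number from compound 2 to compound 3 (0.78 log units; beyond the scatter) for 1-(tert-butoxycarbonyl)pyrrolidin-3-yl in place of 1-(tert-butoxycarbonyl)azetidin-3-yl, and it runs the same way as the earlier step read backwards, so the azetidine compound 2 has the highest number with a pyrrolidine on either configuration lying lower. The configuration of the pyrrolidine stereocentre shows no readable effect at this position, with a 1.3-fold lower number from compound 1 to compound 3 (0.12 log units; within the scatter), which places the drawn configuration within the scatter and leaves the four-membered against five-membered ring change as the only difference here that exceeds it. This reading of the stereocentre is a direct one, and it rests on a single point: the fact that compounds 1 and 3 differ only in the configuration as drawn.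

Going by these compounds, all three compounds keep the tert-butoxycarbonyl group on the ring nitrogen, so it remains open whether a free amine or an acetyl group there would hold the numbers of compound 1 and compound 3. On these data alone, whether the trend continues beyond these two ring sizes also stays open, as a piperidin-4-yl group on the same nitrogen would be needed to test it.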